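From a Carboxy Group to a Methylcarbamoyl Group

The source may report more compounds than this note shows. Statements on the series, on what has been measured and on what is new or still open speak of the compounds shown alone.

Three compounds that share one core have been run through a functional assay on HEK293 cells for agonist activity at Glucose-dependent insulinotropic receptor (Homo sapiens), read by reporter gene assay and cAMP accumulation, with a stated time of 6 h; a lower number here means that less compound is needed, a higher number that more compound is needed for the effect. Compound 1 `O=C(O)C1CCN(c2nc(-c3cc(F)c(Cl)cc3F)nc3c2CS(=O)(=O)C3)CC1` gives 560 nM in this assay and so stands highest of the three numbers. Compound 2 `NC(=O)CN1CCN(c2nc(-c3cc(F)c(Cl)cc3F)nc3c2CS(=O)(=O)C3)CC1` gives 44 nM, and compound 3 `O=S1(=O)Cc2nc(-c3cc(F)c(Cl)cc3F)nc(N3CCC(CCO)CC3)c2C1` gives 2.8 nM. Both measured steps that leave compound 1 are large: a 13-fold lower number from compound 1 to compound 2 (1.10 log units; beyond the scatter), and a 200-fold lower number from compound 1 to compound 3 (2.30 log units; beyond the scatter). Between the other two compounds, a 16-fold lower number from compound 2 to compound 3 (1.20 log units; beyond the scatter).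

Compound 4 `CNC(=O)C1CCN(c2nc(-c3cc(F)c(Cl)cc3F)nc3c2CS(=O)(=O)C3)CC1` has not yet been measured. It differs from compound 1 in one place: methylamino in place of hydroxy on a carbonyl carbon. The carboxy group thereby becomes a methylcarbamoyl group while the rest of the molecule is unchanged. The two measured steps away from compound 1 each replace the carboxy group, and each lowers the number by a wide margin, the smaller of them being the move to compound 2, which also carries a carbamoyl group. Within the data shown here, on that basis a step downward well beyond the scatter is expected for compound 4, although no measured pair here tests a methylcarbamoyl group itself, so the size is uncertain. The step from compound 1 to compound 4 is expected to be a 14-fold lower number from compound 1 to compound 4 (1.15 log units; beyond the scatter). Compound 4 is therefore estimated at 40 nM in this assay, within a range from 8 nM to 200 nM.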

Compound 4, effective concentration (reported as EC, without a stated level of effect): 51 nM
For compound 4 the middle estimate is 1.3-fold (0.11 log units) below the measured one, and the stated range covers the measured number.
By their numbers in this assay, from the lowest: compound 3; then compounds 2 and 4 (each within the scatter of the next); then compound 1.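

In this assay, among these compounds, the single change on the carbonyl carbon, methylamino in place of hydroxy, gives an 11-fold lower number from compound 1 to compound 4 (1.04 log units; beyond the scatter) and so shows that the 4-carboxypiperidin-1-yl group need not be given up as a whole for the number to fall, which compound 2 could not show with its different 4-(carbamoylmethyl)piperazin-1-yl group. That group and 4-(methylcarbamoyl)piperidin-1-yl are not told apart here, with a 1.2-fold higher number from compound 2 to compound 4 (0.06 log units; within the scatter), while on the saturated ring carbon the replacement of 2-hydroxyethyl by methylcarbamoyl gives an 18-fold higher number from compound 3 to compound 4 (1.26 log units; beyond the scatter), so the amide of compound 4 does not reach what the alcohol of compound 3 reaches. Nothing available here accounts for any of these steps.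

The compounds shown leave open how the number responds to an ethylamino or dimethylamino group on the same carbonyl carbon, or to a plain carbamoyl group there with no methyl on the nitrogen. They also leave open whether a methoxyethyl group or a longer hydroxyalkyl chain on the saturated ring carbon would keep the number of compound 3.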